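Swapping cyclopropylamino for methoxy in compound 1

The source may hold more compounds than are shown below. What is called first, only, known or untested is meant among the compounds shown, and "the series" means these compounds.

Compound 1 `COc1nc(NC2CC2)c2ncn([C@H]3C[C@H](N=[N+]=[N-])[C@@H](CO)O3)c2n1` carries an azide and a hydroxymethyl group on its sugar-like ring, and a methoxy and a cyclopropylamino group on the shared core. In an ADME assay on CCRF-CEM cells (Homo sapiens) for cytotoxicity, with a stated time of 5 days (on this read-out higher numbers stand for weaker inhibition and lower numbers for stronger inhibition), compound 1 gives > 100000 nM, which is a limit of the assay and not a number. Compound 2 `CC(C)(CO)Nc1nc(N)nc2c1ncn2[C@H]1C[C@H](N=[N+]=[N-])[C@@H](CO)O1` gives > 100000 nM, also a limit. Compound 3 `[N-]=[N+]=N[C@H]1C[C@H](n2cnc3c(NC4CC4)nc(Cl)nc32)O[C@@H]1CO` gives > 100000 nM, again a limit. Compound 1 therefore has no measured neighbour to rank against, and the whole set looks the same: the limit of > 100000 nM in this assay, at which 3 of the 3 values shown sit.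

Compound 4 `COc1nc(OC)c2ncn([C@H]3C[C@H](N=[N+]=[N-])[C@@H](CO)O3)c2n1` changes one place in compound 1: methoxy in place of cyclopropylamino on an aromatic carbon. Among the compounds with values here, the only measured step from compound 1 is a step that the two limits leave unreadable from compound 1 to compound 3, with chloro in place of methoxy on an aromatic carbon. That step leaves the cyclopropylamino group untouched and gives no size to carry over.

The expectation therefore rests on compound 1 at > 100000 nM, a limit, and on the two other compounds also sitting at that limit. No shift beyond the usual scatter is expected in this assay, so the estimated change is a number no higher from compound 1 to compound 4 (the limit leaves the size open). Compound 4 is estimated at 100000 nM, with an expected range from 50000 nM to 200000 nM, most likely reported again as a limit.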

Compound 4, half-maximal inhibitory concentration: > 100000 nM
Compound 4: a limit, no number; the forecaster's own chance of this, stated with the estimate: 85%; the middle value lies on the limit itself.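

In this assay compound 1 and compound 4 both end at a limit and not at a number, so no step can be read between them. The compounds shown leave open how strong any of them is and whether methoxy in place of cyclopropylamino changes the read-out at all: the limit of > 100000 nM in this assay, at which 4 of the 4 values shown sit.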